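Replacing 2-oxopiperidin-1-yl with 1H-imidazol-2-yl

The compounds below may be only part of what the source reports. "The series", "measured", "known", "first", "only" and "open" are said of these compounds alone.

Measured so far:
compound 1 `CCn1ncc2c(F)cc(-c3ccc(C(CC)(CC)c4nnc[nH]4)c(=O)[nH]3)cc21`: 29 nM
compound 2 `CC(C)C(c1ccc(-c2ccc3cccc(F)c3c2)[nH]c1=O)N1CCCCC1=O`: 40 nM

In a functional assay on CHO cells for antagonist activity at prostaglandin E2 receptor EP3 subtype (Homo sapiens), read by cAMP accumulation (a lower number here means a stronger inhibitor, a higher number a weaker inhibitor), compound 2 gives 40 nM, the higher of the two numbers, while compound 1 gives 29 nM; the gap between them lies within the scatter. Compound 3 `CC(C)C(c1ncc[nH]1)c1ccc(-c2ccc3cccc(F)c3c2)[nH]c1=O` differs from compound 2 in one place: 1H-imidazol-2-yl in place of 2-oxopiperidin-1-yl on a saturated chain carbon bound to an aromatic carbon and a saturated chain carbon. Among the compounds with values here, no step between measured compounds covers this change. Within the data shown here, the only guide is compound 1, which also carries a five-membered aromatic ring with a hydrogen-bond donor and gives 29 nM. The step of a 1.3-fold higher number from compound 2 to compound 3 (0.10 log units; within the scatter) is therefore expected to be small, not clearly beyond the scatter in either direction. Compound 3 is estimated at 50 nM, within 15 nM to 200 nM.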

Compound 3, half-maximal inhibitory concentration: 33 nM
Estimate against measurement, compound 3: 1.5-fold (0.18 log units) above, and the stated range covers the measured number.
By their numbers in this assay, from the lowest: compounds 1, 3 and 2 (each within the scatter of the next).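

In this assay, 1H-imidazol-2-yl in place of 2-oxopiperidin-1-yl gives a 1.2-fold lower number from compound 2 to compound 3 (0.08 log units; within the scatter), so this change leaves the number within the scatter. On this saturated chain carbon, a five-membered aromatic ring with a hydrogen-bond donor and a six-membered non-aromatic ring without one therefore give matching results. Nothing available explains this match. Within the data shown here, only this one swap can be read at this carbon, so it remains open whether a carboxylic acid, an amine or a longer chain there would also stay within the scatter.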